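Working notes on the series: compound 2 to compound 3

The source may report more compounds than this note shows. Statements on the series, on what has been measured and on what is new or still open speak of the compounds shown alone.

Of the compounds shown here, two have been measured: compound 1 `OB1OCc2ccc(-n3cc(Sc4ccccc4O)c4ccccc43)cc21` and compound 2 `O=C(c1ccn(-c2ccc3c(c2)B(O)OC3)c1)c1ccc(Cl)cc1Cl`, both in an ADME assay on L929 cells (Mus musculus) for cytotoxicity, read by resazurin assay, with a stated time of 72 h; on this read-out higher numbers stand for weaker inhibition and lower numbers for stronger inhibition. Compound 1 gives only a limit there, > 10 ug/mL, and no number. Compound 2 likewise gives only a limit in this assay, > 10 ug/mL. Going by the values given here, compound 2 thus stands at the limit of > 10 ug/mL in this assay, at which 2 of the 2 values shown sit; with no number for either compound, no step between the measured compounds can be read and no ordering is possible. The next compound, compound 3 `CCc1ccc(C(=O)c2ccn(-c3ccc4c(c3)B(O)OC4)c2)cc1`, is to be measured in this assay. It differs from compound 2 in one place: 4-ethylphenyl in place of 2,4-dichlorophenyl on a carbonyl carbon. Among the compounds with values here, with no measured step available and both values sitting at the limit, the expected step is a step that the limit leaves unreadable from compound 2 to compound 3, none beyond the usual scatter, most likely ending at the limit once more. Compound 3 is accordingly estimated at 20 ug/mL in this assay, within 8 ug/mL to 50 ug/mL.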

Compound 3, half-maximal inhibitory concentration: > 10 ug/mL
Compound 3: only a limit was reported (the forecaster's own chance of this, stated with the estimate: 70%); the middle value lies beyond the limit too.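

Compound 2 and compound 3 both give only limits in this assay, so no step between them can be read: the limit of > 10 ug/mL in this assay, at which 3 of the 3 values shown sit.

The compounds shown leave open whether 4-ethylphenyl in place of 2,4-dichlorophenyl on a carbonyl carbon changes the read-out at all, and what number any of the three compounds would take.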